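Swapping the chlorinated ring for an ethyl-bearing one

This account rests on a few compounds, and the source may have more. Where it says the series, first, only, none or still open, it means among the compounds named here.

Measured compounds:
Compound 1, `CCCc1cc(NC)c2cc(NC(=O)/C=C/c3ccc(C(F)(F)F)cc3)ccc2n1` — 150 nM
Compound 2, `CCCc1cc(N)c2cc(NC(=O)/C=C/c3ccc(Cl)cc3Cl)ccc2n1` — 904 nM
Compound 3, `CC(C)c1cc(N)c2cc(NC(=O)/C=C/c3ccc(C(F)(F)F)cc3)ccc2n1` — 160 nM

All three compounds were tested in a functional assay on HEK293 cells for activation of melanin-concentrating hormone receptor 1 (Homo sapiens), read by inositol phosphate accumulation; a lower number here means that less compound is needed, a higher number that more compound is needed for the effect. Compound 2, with its 2,4-dichlorophenyl ring at the end of the double-bonded chain, gives 904 nM, the highest of the three numbers. Compound 3 gives 160 nM, and compound 1 gives 150 nM; both of these carry a trifluoromethyl-bearing ring instead, and both lie well beyond the scatter from compound 2. Compound 1 and compound 3 also differ from compound 2 elsewhere, so no single change can be read off from any pair.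

Compound 4, `CCCc1cc(N)c2cc(NC(=O)/C=C/c3ccc(CC)cc3)ccc2n1`, has not been measured. It differs from compound 2 in one place: 4-ethylphenyl in place of 2,4-dichlorophenyl on a double-bonded chain carbon bound to a double-bonded chain carbon.

Since the two compounds with a single substituent on that ring sit far below compound 2, a move back toward their region is expected, though the ethyl group is new to this series and the step may be smaller. The expected step is a 3.0-fold lower number from compound 2 to compound 4 (0.48 log units; beyond the scatter). Compound 4 is therefore estimated at 300 nM, with a range from 100 nM to 900 nM.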

Compound 4, half-maximal effective concentration: 160 nM
For compound 4 the middle estimate is 1.9-fold (0.27 log units) above the measured one; the range from low to high includes it.
By their numbers in this assay, from the lowest: compounds 1, 3 and 4 (each within the scatter of the next); then compound 2.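

In this assay, within the data shown here, the exchange of 2,4-dichlorophenyl for 4-ethylphenyl gives a 5.7-fold lower number from compound 2 to compound 4 (0.75 log units; beyond the scatter) and this is the first comparison in the set that changes one place only, so the whole difference belongs to that exchange on a double-bonded chain carbon bound to a double-bonded chain carbon. The two groups match in every count available: each has 8 heavy atoms, one six-membered aromatic ring of carbon only, no hydrogen-bond donors or acceptors and no net charge, yet the number still moves beyond the scatter, so these counts do not capture what matters at this position. No measurement shown here accounts for the size of this step.

Going by these compounds, whether the step comes from losing the two chlorines or from gaining the ethyl stays open, since this one exchange does both at once. A 4-chlorophenyl or a 4-propylphenyl ring in the same place, with the rest of compound 4 unchanged, would begin to separate the two and show how much room this position has for a longer chain.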